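The source may report more compounds than this note shows. Statements on the series, on what has been measured and on what is new or still open speak of the compounds shown alone.

Compound 1 `COc1ccc(C(=O)/C=C/c2ccc(F)cc2)c2c1C=CC(C)(C)O2` gives > 10000 nM in a functional assay on HCT-116 cells (Homo sapiens) for antiproliferative activity, read by MTT assay, with a stated time of 24 h; a higher number here means a weaker inhibitor, a lower number a stronger inhibitor.
Compound 2 `COc1ccc(C(=O)/C=C/c2ccc(N3CCCC3)cc2)c2c1C=CC(C)(C)O2` gives 8590 nM in this assay.
Compound 3 `COc1ccc(C(=O)/C=C/c2ccc(C(F)(F)F)cc2)c2c1C=CC(C)(C)O2` gives > 10000 nM in this assay.

The value for compound 1 is a limit of this assay, not a measured number. Compound 3 also stands at a limit, as noted in the limit of > 10000 nM in this assay, at which 2 of the 3 values shown sit. Within the data shown here, compound 2 is the only one with a number, and that number is high. The three measured steps all change a group on the aromatic carbon of the side ring: an at least 1.1-fold lower number from compound 1 to compound 2 (0.06 log units; that floor lies within the scatter), a step that the two limits leave unreadable from compound 1 to compound 3 and an at least 1.1-fold higher number from compound 2 to compound 3 (0.06 log units; that floor lies within the scatter). None of them is readable beyond the scatter, and none exchanges the ring itself.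

Compound 4 `COc1ccc(C(=O)/C=C/c2ccsc2)c2c1C=CC(C)(C)O2` differs from compound 1 in exactly that way: thiophen-3-yl in place of 4-fluorophenyl on a double-bonded chain carbon bound to a double-bonded chain carbon. Among the measured compounds shown here, no measured step tests a change of this kind, so the expectation rests only on the weak activity of all three known compounds. Compound 4 is therefore expected to give about 12000 nM, within 4000 nM to 40000 nM, most likely again reported as a limit. For compound 4 this amounts to an expected step that the limit leaves unreadable from compound 1 to compound 4, none beyond the scatter.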

Compound 4, half-maximal inhibitory concentration: > 10000 nM
Compound 4: a limit, no number; the forecaster's own chance of this, stated with the estimate: 60%; the middle value does not contradict the limit.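

Compound 1 and compound 4 both stand at a limit of the assay rather than at a measured number, so no step between them can be read: the limit of > 10000 nM in this assay, at which 3 of the 4 values shown sit.

The compounds shown leave open whether thiophen-3-yl in place of 4-fluorophenyl changes the activity at all in this assay.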